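From 2,4-difluorophenyl to 4-cyano-2-oxopyrrolidin-1-yl on a shared core

A few compounds are considered here, and "the series" means these few. Any claim that something is new, unique, unknown or untested is made for them only; others in the source may bear on it.

Going by the values given here, compound 2 `O=C(Nc1cc(F)c(F)c(F)c1)N1Cc2c(-c3ccc(F)cc3F)cnn2CC1C1CC1` gives 32100 nM in a toxicity assay on HepG2 2.2.15 cells (Homo sapiens) for cytotoxicity, read by CellTiter-Glo (on this read-out higher numbers stand for lower toxicity in this test and lower numbers for higher toxicity in this test), the only exact number so far, so it has no measured neighbour to be ranked against. Compound 3 `N#CC1CC(=O)N(c2cnn3c2CN(C(=O)Nc2cc(F)c(F)c(F)c2)C(C2CC2)C3)C1` has not yet been measured. It keeps the core of compound 2 but carries 4-cyano-2-oxopyrrolidin-1-yl in place of 2,4-difluorophenyl on an aromatic carbon. Among the compounds with values here, no measured step isolates this change, so any expectation is rough. Within the data shown here, the one clue is compound 1 `O=C1CC(Oc2ncccn2)CN1c1cnn2c1CN(C(=O)Nc1cc(F)c(F)c(F)c1)C(C1CC1)C2`, which also has a five-membered non-aromatic ring with 1 hetero atom in that place and gives > 200000 nM, a limit of the assay and not a number. A step toward lower toxicity in this assay, beyond the usual scatter, is therefore expected. The expected size is a 4.7-fold higher number from compound 2 to compound 3 (0.67 log units; beyond the scatter). For compound 3 the estimate is 150000 nM, within an expected range of 60000 nM to 200000 nM.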

Compound 3, half-maximal cytotoxic concentration: > 200000 nM
Compound 3 gave a limit, no number (the forecaster's own chance of this, stated with the estimate: 55%); middle value at least 1.3-fold (0.12 log units) away from the limit.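

Putting 4-cyano-2-oxopyrrolidin-1-yl in place of 2,4-difluorophenyl on this aromatic carbon now has a directly measured effect in this assay: an at least 6.2-fold higher number from compound 2 to compound 3 (0.79 log units; beyond the scatter). Compound 3 gives > 200000 nM, which is a limit of the assay and not a number. The step from compound 1 to compound 3, with cyano in place of (pyrimidin-2-yl)oxy on a saturated ring carbon, cannot be read, so these two groups cannot be ordered in this assay: the limit of > 200000 nM in this assay, at which 2 of the 3 values shown sit.

The compounds shown leave open which part of the new group goes with the higher number: the five-membered ring, its carbonyl or its nitrile. They also leave open how an unsubstituted phenyl or an open-chain amide on this aromatic carbon would read in this assay.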